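The source may hold more compounds than are shown below. What is called first, only, known or untested is meant among the compounds shown, and "the series" means these compounds.

Of the compounds shown here, three built on a shared core have been tested for how harmful they are to a human cell line. Compound 1 `CCCC(=O)Nc1ncc(-c2ccc(OC)cc2)n1C` carries a propyl on the carbonyl carbon. In a toxicity assay on THP-1 cells (Homo sapiens) for inhibition (on this read-out lower numbers stand for higher toxicity in this test and higher numbers for lower toxicity in this test), compound 1 gives > 100000 nM, which is a limit of the assay rather than a number. Compound 2 `COc1ccc(-c2cnc(NC(=O)c3cnc[nH]3)n2C)cc1` carries a 1H-imidazol-5-yl on that carbonyl carbon, and in this assay compound 2 gives > 100000 nM, again a limit. Compound 3 `COc1ccc(-c2cnc(NC(=O)c3ccc(O)cc3)n2C)cc1` carries a 4-hydroxyphenyl there, and in this assay compound 3 gives > 100000 nM, also a limit. Because every value sits at the limit of > 100000 nM in this assay, at which 3 of the 3 values shown sit, the steps a step that the two limits leave unreadable from compound 1 to compound 2, a step that the two limits leave unreadable from compound 1 to compound 3 and a step that the two limits leave unreadable from compound 2 to compound 3 cannot be read. Compound 3 therefore stands where every measured compound stands, at the limit, with no number to compare against.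

Compound 4 `COc1ccc(-c2cnc(NC(=O)c3cccc(Cl)c3)n2C)cc1` differs from compound 3 in one place: 3-chlorophenyl in place of 4-hydroxyphenyl on a carbonyl carbon. Within the data shown here, every earlier exchange on this carbonyl carbon left the read-out at the limit, so no measured step gives a readable size for this kind of change, and no step beyond the scatter is expected in either direction. The step of a number no higher from compound 3 to compound 4 (the limit leaves the size open) is expected to be close to nil. Compound 4 is estimated at 100000 nM, within 30000 nM to 300000 nM, and the assay is expected most likely to report only a limit again.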

Compound 4, half-maximal cytotoxic concentration: > 28000 nM
Compound 4: no number, only a limit (the forecaster's own chance of this, stated with the estimate: 75%); the middle value lies beyond the limit too.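

In this assay compound 4 gives > 28000 nM, again a limit of the assay and not a number. None of the steps from compound 1, compound 2 or compound 3 to compound 4 can be read. The compounds shown leave open how toxic any of the four is, and whether any exchange on the carbonyl carbon changes that toxicity.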